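Anilino to pyrrolidin-1-yl in an inactive pair

The compounds below may be only part of what the source reports. "The series", "measured", "known", "first", "only" and "open" are said of these compounds alone.

In a functional assay on HeLa cells (Homo sapiens) for inhibition, read by sulforhodamine B assay (on this read-out higher numbers stand for weaker inhibition and lower numbers for stronger inhibition), compound 1 `O=C1C(Nc2ccccc2)=CC(=O)c2c1nc1n2[C@H]2OC[C@@H](O)[C@H]2OC1` reads > 8000 nM, which is a limit and not a number. In this assay, compound 2 `O=C1C=C(NC2CCCCC2)C(=O)c2c1nc1n2[C@H]2OC[C@@H](O)[C@H]2OC1` reads > 16000 nM, again a limit. Compound 3 `O=C1C(N2CCCC2)=CC(=O)c2c1nc1n2[C@H]2OC[C@@H](O)[C@H]2OC1` has pyrrolidin-1-yl in place of anilino on a double-bonded ring carbon. Among the measured compounds shown here, no measured step is available as a guide, and no step beyond the scatter is expected in this assay. The expected change is a step that the limit leaves unreadable from compound 1 to compound 3, and a further limit is quite possible. For compound 3 the estimated value is 12000 nM, with an expected range of 4000 nM to 30000 nM.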

Compound 3, half-maximal inhibitory concentration: > 16000 nM
Compound 3 was reported as a limit; the forecaster's own chance of this, stated with the estimate: 60%; middle value at least 1.3-fold (0.12 log units) away from the limit.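

No step can be read between compound 1 and compound 3 in this assay: both values are limits, not numbers. The compounds shown leave open whether anilino and pyrrolidin-1-yl differ at all in this inhibition.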